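Thiosemicarbazide series: piperidine in place of thiomorpholine

The source may hold more compounds than are shown below. What is called first, only, known or untested is meant among the compounds shown, and "the series" means these compounds.

Working notes on the amidrazone thiosemicarbazides tested in a functional assay on MCF7 cells (Homo sapiens) for cytotoxicity, read by MTT assay, with a stated time of 72 h, tested at 1 uM; on this read-out higher numbers stand for more inhibition of growth at the one concentration tested and lower numbers for less inhibition of growth. Three compounds have numbers. Compound 1 `Cc1ccnc(/C(N)=N/NC(=S)N2CCN(c3ccccn3)CC2)c1` gives 21%, compound 3 `N/C(=N\NC(=S)N1CCSCC1)c1ccccn1` gives 16.3%, and compound 2 `Cc1ccnc(/C(N)=N/NC(=S)N2CCSCC2)c1` gives 3.89%, the lowest of the three; its nearest neighbour on the numbers is compound 3, the furthest is compound 1, both beyond the scatter.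

Within the data shown here, the one step between two compounds that differ in a single place is a number 12.4 percentage points higher from compound 2 to compound 3 (beyond the scatter), a change on the aromatic ring of the shared core, far from the thiocarbonyl carbon. Compound 1 and compound 2 differ at the thiocarbonyl carbon, but by more than a simple swap of one ring for another of the same kind, so their two values only show that a different ring there can go with a higher number.

Compound 4 `Cc1ccnc(/C(N)=N/NC(=S)N2CCCCC2)c1` arises from compound 2 by piperidin-1-yl in place of thiomorpholin-4-yl on a thiocarbonyl carbon. Among the measured compounds shown here, no measured step bears directly on this change; the step from compound 2 to compound 3 concerns another place. The expectation is therefore a step of a number 5.1 percentage points higher from compound 2 to compound 4 (within the scatter) in this assay, most likely none beyond the scatter, with a lean upwards because compound 2 sits at 3.89% and has little room to fall. Compound 4 is estimated at 9%, within a range of 0% to 22%.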

Compound 4, percent growth inhibition at one concentration: 21.2%
Compound 4: middle estimate off by 12.2 percentage points, on the low side; the measured number falls inside the stated range.
By their numbers in this assay, from the lowest: compound 2; then compounds 3, 1 and 4 (each within the scatter of the next).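

In this assay the thiocarbonyl carbon now has a single-place step of its own, a number 17.3 percentage points higher from compound 2 to compound 4 (beyond the scatter) with piperidin-1-yl in place of thiomorpholin-4-yl. Among these compounds, the earlier single-place step lay on the aromatic ring of the shared core, and compound 1 differs from compound 2 by more than a swap of one ring for another of the same kind, so this is the first reading to show that changing the ring on the thiocarbonyl carbon alone can move the number beyond the scatter, and that in this pair the higher number does not need the ring sulfur of thiomorpholin-4-yl. No measurement at hand accounts for this step, which stands as an observation on one pair of compounds.

As far as these compounds go, whether the same ring change gives a comparable step on the core of compound 3, which carries hydrogen in place of methyl on an aromatic carbon, remains open. Also open, from the compounds shown here alone, is what morpholin-4-yl, with oxygen in the place of that ring sulfur, or an open-chain dimethylamino group would give on the thiocarbonyl carbon.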